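The source may report more compounds than this note shows. Statements on the series, on what has been measured and on what is new or still open speak of the compounds shown alone.

Of the compounds shown here, three sharing one core have been measured in a functional assay on MDA-MB-436 cells (Homo sapiens) for antiproliferative activity, read by MTT assay, with a stated time of 48 h; on this read-out higher numbers stand for weaker inhibition and lower numbers for stronger inhibition. Compound 1 `C=CS(=O)(=O)N1CCN(c2ncnc3sc(-c4cccc5ccccc45)cc23)CC1` gives 28100 nM; compound 2 `C=CS(=O)(=O)N1CCN(c2ncnc3sc(-c4ccnc(Cl)c4)cc23)CC1` gives 30100 nM; compound 3 `C=CS(=O)(=O)N1CCN(c2ncnc3sc(-c4ccc(F)nc4)cc23)CC1` gives 17500 nM. Compound 3 thus does not stand apart from either neighbour: a 1.6-fold lower number from compound 1 to compound 3 (0.21 log units; within the scatter) and a 1.7-fold lower number from compound 2 to compound 3 (0.24 log units; within the scatter), so all three are indistinguishable in this assay. Swapping one flat aromatic group for another at this position has so far produced only small movements, and that is the kind of change now made again. Compound 4 `C=CS(=O)(=O)N1CCN(c2ncnc3sc(-c4c(C)noc4C)cc23)CC1` differs from compound 3 in one place: 3,5-dimethyl-1,2-oxazol-4-yl in place of 6-fluoropyridin-3-yl on an aromatic carbon. Both steps leading into compound 3 bear on this, and both were small, so the expectation is that compound 4 will behave like its three predecessors. The estimated step is a 1.3-fold higher number from compound 3 to compound 4 (0.10 log units; within the scatter), a movement that would be expected to stay within the scatter. Compound 4 is therefore estimated at 22000 nM, with a likely range from 9000 nM to 55000 nM.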

Compound 4, half-maximal inhibitory concentration: 34600 nM
Beside the measured number, compound 4's estimate is 1.6-fold (0.20 log units) below it; low and high end bracket the measured number.
By their numbers in this assay, from the lowest: compounds 3, 1, 2 and 4 (each within the scatter of the next).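

In this assay, a five-membered aromatic ring, 3,5-dimethyl-1,2-oxazol-4-yl, reads the same as the earlier pyridinyl and naphthalenyl groups, with a 2.0-fold higher number from compound 3 to compound 4 (0.30 log units; within the scatter) and a 1.1-fold higher number from compound 2 to compound 4 (0.06 log units; within the scatter) and also a 1.2-fold higher number from compound 1 to compound 4 (0.09 log units; within the scatter). Changing ring size and hetero atoms at this carbon, next to the ring sulfur, therefore does not set compound 4 apart, and all four compounds remain indistinguishable here. No further measurement bears on why these different rings read alike.

As far as these compounds go, all four groups are aromatic rings, so it remains open whether an amine, a carboxylic acid or a longer chain at this carbon would move the number beyond the scatter. From the compounds shown here alone, the rest of the molecule is the same throughout, so its contribution also remains open.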